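This account rests on a few compounds, and the source may have more. Where it says the series, first, only, none or still open, it means among the compounds named here.

Measured so far:
Compound 1, `NC(=O)C[C@H](NC(=O)CN(c1nc(Cl)nc2[nH]cnc12)C1CC1)C(=O)O`, in a functional assay on the whole organism (Tail, strain ICR) with Mus musculus as the target, in the tail flick test, with a stated time of 60 min, at a dose of 25 umol/kg by the oral route; a higher number here means a stronger effect of the compound at the dose given, a lower number a weaker effect: 43.1%
Compound 2, `NCCCC[C@H](NC(=O)CN(c1nc(Cl)nc2[nH]cnc12)C1CC1)C(=O)OCc1ccccc1`, in this assay: 41.2%

Compound 1 and compound 2 give numbers that lie within the usual scatter of each other, so neither can be set above the other. Compound 3, `NC(=O)CC[C@H](NC(=O)CN(c1nc(Cl)nc2[nH]cnc12)C1CC1)C(=O)O`, has not yet been measured. It differs from compound 1 in one place: carbamoylmethyl in place of carbamoyl on a saturated chain carbon, two bonds along the chain from an amide-type nitrogen and a carbonyl carbon. Among the compounds with values here, no measured pair shows a change of this kind, so nothing beyond the scatter is expected, and the step is estimated as a number 3.1 percentage points lower from compound 1 to compound 3 (within the scatter). Compound 3 is expected to give about 40%, with a range from 20% to 60%.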

Compound 3, a percentage reported as activity, at one dose (the size of the read-out at that dose, not a potency): 38.4%
Beside the measured number, compound 3's estimate is 1.6 percentage points above it; low and high end bracket the measured number.
By their numbers in this assay, from the lowest: compounds 3, 2 and 1 (each within the scatter of the next).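

Within the data shown here, compound 3 gives the first comparison that changes a single place on the shared core: with carbamoylmethyl in place of carbamoyl on this saturated chain carbon, this assay shows a number 4.7 percentage points lower from compound 1 to compound 3 (within the scatter). At this dose, this position therefore tolerates the change without a readable shift in effect. Nothing measured here gives a reason for this result.

Still open, going by these compounds, is whether a carboxylic acid or a longer chain in place of carbamoylmethyl on this carbon would move the effect beyond the scatter. A single dose and time also leave open whether the same holds at other doses and times.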